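The source may report more compounds than this note shows. Statements on the series, on what has been measured and on what is new or still open speak of the compounds shown alone.

In a functional assay (trachea) for inhibition, with Cavia porcellus as the target (a lower number here means a stronger inhibitor, a higher number a weaker inhibitor), compound 1 `CCc1ccc2c(c1)C(C)(C)[C@@H](O)[C@@H]2N1CCCCC1=O` gives > 20000 nM, a limit and not a number. Compound 2 `CC1(C)c2cc(C(F)(F)F)ccc2[C@@H](N2CCCCC2=O)[C@@H]1O` gives > 20000 nM, also a limit. Compound 3 `CC1(C)c2cc(C#N)ccc2[C@@H](N2CCCCC2=O)[C@@H]1O` gives > 20000 nM, again a limit. Compound 2 thus stands at the limit of > 20000 nM in this assay, at which 3 of the 3 values shown sit. The measured steps, a step that the two limits leave unreadable from compound 1 to compound 2, a step that the two limits leave unreadable from compound 1 to compound 3 and a step that the two limits leave unreadable from compound 2 to compound 3, all concern a group on an aromatic carbon and give no size. Compound 4 `CC1(C)c2cc(C(F)(F)F)ccc2[C@@H](n2ccccc2=O)[C@@H]1O` differs from compound 2 in one place: a group of 7 heavy atoms (5 carbon, 1 nitrogen, 1 oxygen; one six-membered aromatic ring with 1 hetero atom) in place of a group of 7 heavy atoms (5 carbon, 1 nitrogen, 1 oxygen; one six-membered non-aromatic ring with 1 hetero atom), on a saturated ring carbon. For the measured compounds named here, no measured step touches this group, so no size carries over, and no definite direction is expected in this assay. The expected outcome is a reading close to the limit, possibly a limit again. The estimated step is a number no higher from compound 2 to compound 4 (the limit leaves the size open). For compound 4 the expected value is 20000 nM, with an estimated range of 4000 nM to 40000 nM.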

Compound 4, half-maximal inhibitory concentration: > 20000 nM
Compound 4 ended at the assay's limit; the forecaster's own chance of this, stated with the estimate: 60%; the middle value sits exactly at the limit.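

In this assay compound 2 and compound 4 both stand at a limit, and no new step can be read between them. The compounds shown leave open how far any of these changes on the shared core moves inhibition: no reading here is a number.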